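A few compounds are considered here, and "the series" means these few. Any claim that something is new, unique, unknown or untested is made for them only; others in the source may bear on it.

Measured compounds:
Compound 1, `CC(C)=CC[C@@H](OC(=O)CCO)C1=CC(=O)c2c(O)ccc(O)c2C1=O`: in a functional assay on DU-145 cells (Homo sapiens) for cytotoxicity, read by MTT assay (on this read-out higher numbers stand for weaker inhibition and lower numbers for stronger inhibition), compound 1 gives 55300 nM.
Compound 2, `CCCC(CC(=O)O[C@H](CC=C(C)C)C1=CC(=O)c2c(O)ccc(O)c2C1=O)OC(C)=O`: in this assay compound 2 gives 55700 nM.
Compound 3, `CCCC(C)(O)CC(=O)O[C@H](CC=C(C)C)C1=CC(=O)c2c(O)ccc(O)c2C1=O`: in this assay compound 3 gives 75000 nM.

Compound 2 holds the second highest of the three numbers; its nearest neighbour is compound 1, with a 1.0-fold higher number from compound 1 to compound 2 (0.00 log units; within the scatter), and its furthest is compound 3, with a 1.3-fold higher number from compound 2 to compound 3 (0.13 log units; within the scatter), so all three values sit within the scatter of one another and no order among them can be read.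

Compound 4, `CCC(O)(CC)CC(=O)O[C@H](CC=C(C)C)C1=CC(=O)c2c(O)ccc(O)c2C1=O`, has not yet been measured. Its difference from compound 2 is 1-ethyl-1-hydroxypropyl in place of 1-acetoxybutyl on a saturated chain carbon bound to a carbonyl carbon. For the measured compounds named here, the step that bears most directly on it is the one from compound 2 to compound 3, which also replaces 1-acetoxybutyl with a group carrying a hydroxy on the chain carbon bound to the carbonyl carbon: a 1.3-fold higher number from compound 2 to compound 3 (0.13 log units; within the scatter). The step of a 1.4-fold higher number from compound 1 to compound 3 (0.13 log units; within the scatter), likewise introducing such a group, is also within the scatter. On these grounds no step beyond the scatter is expected in this assay; the change from compound 2 to compound 4 is estimated as a 1.2-fold higher number from compound 2 to compound 4 (0.07 log units; within the scatter). Compound 4 is expected to give 65000 nM, with a range from 30000 nM to 140000 nM.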

Compound 4, half-maximal inhibitory concentration: 67000 nM
For compound 4 the middle estimate is 1.0-fold (0.01 log units) below the measured one; measured number inside the range.
By their numbers in this assay, from the lowest: compounds 1, 2, 4 and 3 (each within the scatter of the next).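

In this assay, 1-ethyl-1-hydroxypropyl on a saturated chain carbon bound to a carbonyl carbon stays within the scatter of each group compared with it: 1-acetoxybutyl (a 1.2-fold higher number from compound 2 to compound 4 (0.08 log units; within the scatter)), 1-hydroxy-1-methylbutyl (a 1.1-fold lower number from compound 3 to compound 4 (0.05 log units; within the scatter)) and hydroxymethyl (a 1.2-fold higher number from compound 1 to compound 4 (0.08 log units; within the scatter)). The series now has four different groups at this place, with either a free hydroxy or an acetoxy, and none of them separates from the others on this read-out. No supporting data bear on why these values stay so close.

From the compounds shown here alone, whether an amine or a carboxylic acid at this place would move the number beyond the scatter remains open. The same holds for a longer chain carrying the hydroxy, and for any change to the shared core.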